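Replacing trifluoromethyl with nitro on the aryl ring

A few compounds are considered here, and "the series" means these few. Any claim that something is new, unique, unknown or untested is made for them only; others in the source may bear on it.

Measured so far in a functional assay on CWR22R cells (Homo sapiens) for cytotoxicity, read by MTT assay, with a stated time of 72 h; on this read-out higher numbers stand for weaker inhibition and lower numbers for stronger inhibition:
- compound 1 `CC1=CCCC(C)(C)C1/C=C/C(=O)/C=C/c1ccccc1C(F)(F)F`: 18400 nM
- compound 2 `CC1=CCCC(C)(C)C1/C=C/C(=O)/C=C/c1cccc(C(F)(F)F)c1`: 2900 nM
- compound 3 `CC1=CCCC(C)(C)C1/C=C/C(=O)/C=C/c1cc(C(F)(F)F)ccc1F`: 3500 nM

Compound 2 gives the lowest number of the three in this assay. Its nearest neighbour is compound 3, reached by a 1.2-fold higher number from compound 2 to compound 3 (0.08 log units; within the scatter). Within the data shown here, the gap to compound 1 is wide: compound 1 gives 18400 nM, whereas compound 2 gives 2900 nM, and no single step between them is described here beyond what the two values show.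

Compound 4 `CC1=CCCC(C)(C)C1/C=C/C(=O)/C=C/c1cccc([N+](=O)[O-])c1` is not yet measured. It differs from compound 2 by nitro in place of trifluoromethyl on an aromatic carbon. Among the measured compounds shown here, none of the measured steps swaps one group for another at this position; the only step available, from compound 2 to compound 3, adds a fluorine elsewhere and stays within the scatter. For the measured compounds named here, nothing among the measured compounds therefore points to a change in either direction. The expectation for compound 4 in this assay is a number close to that of compound 2, about 3000 nM, within 1000 nM to 9000 nM, which corresponds to an expected step of a 1.0-fold higher number from compound 2 to compound 4 (0.01 log units; within the scatter).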

Compound 4, half-maximal inhibitory concentration: 4700 nM
Compound 4: the middle estimate sits 1.6-fold (0.19 log units) below what was measured; the range from low to high includes it.
By their numbers in this assay, from the lowest: compounds 2, 3 and 4 (each within the scatter of the next); then compound 1.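

In this assay, nitro in place of trifluoromethyl gives a 1.6-fold higher number from compound 2 to compound 4 (0.21 log units; within the scatter), so the two compounds cannot be told apart by this read-out. Among these compounds, this is the first swap of one group for another at this position, and the earlier step, which only added a fluoro elsewhere on the ring, could not show it. Here, a nitro with two hydrogen-bond acceptors replaces a trifluoromethyl with none and the number stays within the scatter, but no measurement here accounts for this. As far as these compounds go, it remains open whether a different kind of group at this position, such as an amine or a carboxylic acid, would leave the number just as unchanged. From the compounds shown here alone, whether nitro would behave the same way elsewhere on the ring also remains open.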